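Compound 2 to compound 4 in the working series

The source may report more compounds than this note shows. Statements on the series, on what has been measured and on what is new or still open speak of the compounds shown alone.

Measured in a functional assay on HT-29 cells (Homo sapiens); a lower number here means that less compound is needed, a higher number that more compound is needed for the effect
- compound 1 `CN(CCN)C(=O)c1cc(-c2ccccc2)sc1NC(N)=O` reads "not determined" (no result reported) and offers no number
- compound 2 `NC(=O)Nc1sc(-c2ccc(C(=O)N3CCCCC3)cc2)cc1C(=O)N[C@H]1CCCNC1` reads 130 nM on this measure
- compound 3 `CC(=O)Nc1cccc(-c2cc(C(=O)N[C@H]3CCCNC3)c(NC(N)=O)s2)c1` reads 1800 nM on this measure

Of the two numbers, compound 2 at 130 nM stands lowest, and compound 3 lies higher, beyond the usual scatter.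

Compound 4 `CS(=O)(=O)c1ccc(-c2cc(C(=O)N[C@H]3CCCNC3)c(NC(N)=O)s2)cc1` is still to be measured in this assay and keeps the core of compound 2. The change is methylsulfonyl in place of (piperidin-1-yl)carbonyl on an aromatic carbon and puts methylsulfonyl in place of (piperidin-1-yl)carbonyl on an aromatic carbon.

Among the compounds with values here, no measured pair differs in one place, so the size of this step rests on thin evidence. A moderate rise beyond the scatter is expected, since compound 3 at 1800 nM shows that a compound without the (piperidin-1-yl)carbonyl group can carry a higher number. The estimated step of a 3.1-fold higher number from compound 2 to compound 4 (0.49 log units; beyond the scatter) is expected to run upward. For compound 4 the estimate is 400 nM with an expected range of 120 nM to 1500 nM as its ends.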

Compound 4, half-maximal effective concentration: 200 nM
Compound 4: middle estimate off by 2.0-fold (0.30 log units), on the high side; measured number inside the range.
By their numbers in this assay, from the lowest: compounds 2 and 4 (each within the scatter of the next); then compound 3.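

In this assay, within the data shown here, the exchange of (piperidin-1-yl)carbonyl for methylsulfonyl on an aromatic carbon, para to a large group, gives a 1.5-fold higher number from compound 2 to compound 4 (0.19 log units; within the scatter) and is the only one-place step so far. At this position, the leaving group's 8 heavy atoms and six-membered non-aromatic ring can thus be replaced by the 4 heavy atoms of methylsulfonyl, which has no ring, with no change beyond the scatter. No supporting data accompany this result, so the step stands without an explanation.

Still open, as far as these compounds go, is whether a carboxylic acid or an aminomethyl group at the same place would also stay within the scatter of compound 2. A single step also leaves open whether the same exchange would read alike with a different amide on the shared core.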